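This account rests on a few compounds, and the source may have more. Where it says the series, first, only, none or still open, it means among the compounds named here.

Compound 1 `O=C(OC[C@H]1O[C@@H](n2cc(F)c(=O)[nH]c2=O)C[C@@H]1OC(=O)[C@@H]1CCCN1)[C@@H]1CCCN1` carries two (pyrrolidin-2-yl)carbonyl groups on oxygens of its shared core. Within the data shown here, in an ADME assay on a cell-free system (plasma, Homo sapiens) for metabolic stability (a lower number here means that the compound disappears faster, a higher number that the compound lasts longer), compound 1 gives 0.1 h, the higher of the two numbers measured so far, though the gap to the other one is within the scatter. Among the measured compounds shown here, compound 2 `O=C(OC[C@H]1O[C@@H](n2cc(F)c(=O)[nH]c2=O)C[C@@H]1O)[C@@H]1CCCN1` keeps only one of those groups and gives 0.095 h in this assay; the step from compound 1 to compound 2 is a 1.1-fold lower number from compound 1 to compound 2 (0.02 log units; within the scatter), so removing one (pyrrolidin-2-yl)carbonyl from an oxygen on a saturated carbon left the half-life unchanged within the scatter.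

Compound 3 `O=C(O[C@H]1C[C@H](n2cc(F)c(=O)[nH]c2=O)O[C@@H]1CO)[C@@H]1CCCN1` has not yet been measured. It differs from compound 1 by hydrogen in place of (pyrrolidin-2-yl)carbonyl on an oxygen on a saturated carbon, the same kind of removal but at the other oxygen, the one on a saturated carbon whose other neighbour is a saturated chain carbon. For the measured compounds named here, because the only measured step bearing on this change, a 1.1-fold lower number from compound 1 to compound 2 (0.02 log units; within the scatter), stayed within the scatter, no step beyond the scatter is expected for compound 3 either. The estimate for compound 3 in this assay is 0.1 h, within 0.05 h to 0.2 h, which means an expected step of no change at the digits printed from compound 1 to compound 3 (within the scatter).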

Compound 3, half-life: 0.23 h
Compound 3: the middle estimate sits 2.3-fold (0.36 log units) below what was measured; measured number above the stated range.
By their numbers in this assay, from the lowest: compounds 2 and 1 (each within the scatter of the next); then compound 3.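

In this assay, taking (pyrrolidin-2-yl)carbonyl off the oxygen on a saturated carbon whose other neighbours are: saturated chain carbon, and leaving hydrogen there, gives a 2.3-fold higher number from compound 1 to compound 3 (0.36 log units; beyond the scatter). The same exchange at the other oxygen of the shared core gave a 1.1-fold lower number from compound 1 to compound 2 (0.02 log units; within the scatter), so the outcome of this removal depends on which of the two oxygens loses the group, and only the removal that leads to compound 3 moves the half-life beyond the scatter. Nothing available here accounts for this difference between the two oxygens.

The compounds shown pair this oxygen only with hydrogen or (pyrrolidin-2-yl)carbonyl, so it remains open whether a small acetyl group or a methyl ether on the same oxygen would give a number closer to that of compound 1 or to that of compound 3. Going by these compounds, it is also open what the half-life would be with hydrogen on both oxygens, or whether a longer chain on the acyl group would change the picture at either oxygen.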